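The compounds below may be only part of what the source reports. "The series", "measured", "known", "first", "only" and "open" are said of these compounds alone.

Compound 1 `CC(C)(C)n1cc2c(n1)C(=O)CC1(CCN(C(=O)c3cc(-c4ccc(F)cc4)nc4ccccc34)CC1)O2`: 2930 nM
Compound 2 `CC(C)(C)n1cc2c(n1)C(=O)CC1(CCN(C(=O)c3cc(-c4ccccn4)nc4ccccc34)CC1)O2`: 1500 nM
Compound 3 `CC(C)(C)n1cc2c(n1)C(=O)CC1(CCN(C(=O)c3cc(Cl)nc4ccccc34)CC1)O2`: 4720 nM

In a functional assay on HepG2 cells (Homo sapiens) for inhibition, read by MTT assay, with a stated time of 72 h (on this read-out higher numbers stand for weaker inhibition and lower numbers for stronger inhibition), compound 1 gives 2930 nM, the second highest of the three numbers; compound 3 sits nearest at 4720 nM, compound 2 furthest at 1500 nM. Compound 4 `COc1cc(C(=O)N2CCC3(CC2)CC(=O)c2nn(C(C)(C)C)cc2O3)c2ccccc2n1` differs from compound 1 by methoxy in place of 4-fluorophenyl on an aromatic carbon.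

The step that bears on this change is a 1.6-fold higher number from compound 1 to compound 3 (0.21 log units; within the scatter), where a small group likewise replaced 4-fluorophenyl and the number stayed within the scatter. The step of a 3.1-fold higher number from compound 2 to compound 3 (0.50 log units; beyond the scatter) shows a modest loss when a small group replaces an aromatic ring on compound 2. Going by the values given here, no measured step covers methoxy itself.

Compound 4 is therefore expected to give 4200 nM, with a range of 1900 nM to 9500 nM. The estimated step of a 1.4-fold higher number from compound 1 to compound 4 (0.16 log units; within the scatter) is expected to stay within the scatter, leaning toward a slightly higher number.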

Compound 4, half-maximal inhibitory concentration: > 10000 nM
Compound 4: a limit, no number; the forecaster's own chance of this, stated with the estimate: 5%; at least 2.3-fold (0.37 log units) between middle value and limit.
By their numbers in this assay, from the lowest: compounds 2, 1 and 3 (each within the scatter of the next, the first and the last beyond it). At a limit, above all of these: compound 4.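

In this assay compound 4 gives > 10000 nM, a limit and not a number. On this aromatic carbon next to the ring nitrogen, methoxy separates from all three other groups, with an at least 3.4-fold higher number from compound 1 to compound 4 (0.53 log units; beyond the scatter), an at least 2.1-fold higher number from compound 3 to compound 4 (0.32 log units; beyond the scatter) and an at least 6.6-fold higher number from compound 2 to compound 4 (0.82 log units; beyond the scatter). Losing the aromatic ring here does not by itself give a reading like that of methoxy, as compound 3, with chloro and no ring at this place, still gives 4720 nM.

As far as these compounds go, whether an amine or a longer alkoxy chain here would read like methoxy or like chloro remains open. From the compounds shown here alone, the full size of the steps to compound 4 also remains open.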